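Compound 3: hydrogen in place of 4-fluorophenyl

The source may report more compounds than this note shows. Statements on the series, on what has been measured and on what is new or still open speak of the compounds shown alone.

Compound 2 (`O=C(NO)c1ccc(/C=C/c2ccnc(-c3ccc(F)cc3)c2)cc1`) stands at > 10000 nM in a functional assay on HCT-116 cells (Homo sapiens) for antiproliferative activity, read by CellTiter-Glo, with a stated time of 72 h (on this read-out lower numbers stand for stronger inhibition and higher numbers for weaker inhibition), a limit and not a number. Compound 3 (`O=C(NO)c1ccc(/C=C/c2ccncc2)cc1`) carries hydrogen in place of 4-fluorophenyl on an aromatic carbon. Going by the values given here, the only measured step at this place, an at least 6.8-fold higher number from compound 1 to compound 2 (0.83 log units; beyond the scatter), exchanged one aryl group for another, starting from compound 1 (`O=C(NO)c1ccc(/C=C/c2ccnc(-c3ccccc3O)c2)cc1`) at 1450 nM in this assay. Among the compounds with values here, no measured step removes the group altogether, so the expectation is loose. The expected change is an at least 2.0-fold lower number from compound 2 to compound 3 (0.30 log units; that floor lies within the scatter), toward a lower number, and it may still end at the limit. Compound 3 is estimated at 5000 nM (range 1200 nM to 20000 nM) in this assay.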

Compound 3, half-maximal inhibitory concentration: 3910 nM
Compound 3: middle estimate off by 1.3-fold (0.11 log units), on the high side; the measured number falls inside the stated range.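

Hydrogen on this aromatic carbon gives a reference without any aryl group in this assay, and the two aryl groups fall on opposite sides of it. Losing 4-fluorophenyl gives an at least 2.5-fold lower number from compound 2 to compound 3 (0.40 log units; beyond the scatter), whereas losing 2-hydroxyphenyl gives a 2.7-fold higher number from compound 1 to compound 3 (0.43 log units; beyond the scatter). Compound 2 stands at a limit and not a number, so the first step has no known full size: the limit of > 10000 nM in this assay, at which 1 of the 3 values shown sits.

Open, going by these compounds, is whether the hydroxyl of 2-hydroxyphenyl carries the difference, which plain phenyl or a methoxy in place of that hydroxyl would test. Also open, on these data alone, is how an amine directly on this carbon compares with hydrogen.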